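A few compounds are considered here, and "the series" means these few. Any claim that something is new, unique, unknown or untested is made for them only; others in the source may bear on it.

Values in a functional assay on HL-60 cells (Homo sapiens) for cytotoxicity, read by WST assay, with a stated time of 48 h (on this read-out lower numbers stand for an effect already at smaller amounts and higher numbers for an effect only at larger amounts of compound), so far
compound 1 `COc1cccc(C[C@H]2C(=O)OC[C@@H]2Cc2ccccc2)c1` gives 66000 nM
compound 2 `C[C@H](Cc1ccccc1)[C@H](C)Cc1ccc(Cl)c(Cl)c1` gives 19000 nM
compound 3 `O=C1OC[C@H](Cc2ccccc2O)[C@H]1Cc1ccc(Cl)c(Cl)c1` gives 33000 nM

The number for compound 3 lies within the scatter of compound 2 and of compound 1 alike. Compound 4 `COc1cccc(C[C@H]2COC(=O)[C@@H]2Cc2ccc(Cl)c(Cl)c2)c1` has 3-methoxyphenyl in place of 2-hydroxyphenyl on a saturated chain carbon bound to a saturated ring carbon. Among the measured compounds shown here, no measured pair yet isolates a single change. Compound 1, which also holds 3-methoxyphenyl though not at the same place, gives 66000 nM and stays within the scatter of compound 3. No step beyond the scatter is therefore expected in this assay, and no direction is favoured. The expected step, a 1.1-fold lower number from compound 3 to compound 4 (0.04 log units; within the scatter), stays within the scatter. For compound 4 the estimated value is 30000 nM, with an expected range from 12000 nM to 70000 nM.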

Compound 4, half-maximal effective concentration: 34000 nM
Compound 4: the middle estimate sits 1.1-fold (0.05 log units) below what was measured; low and high end bracket the measured number.
By their numbers in this assay, from the lowest: compounds 2, 3, 4 and 1 (each within the scatter of the next, the first and the last beyond it).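

Among the compounds shown here, with a 1.0-fold higher number from compound 3 to compound 4 (0.01 log units; within the scatter) in this assay as the first step that changes one place, 3-methoxyphenyl and 2-hydroxyphenyl are not told apart on a saturated chain carbon bound to a saturated ring carbon. At this place, giving up the hydrogen-bond donor and adding a heavy atom leaves the number within the scatter. Nothing at hand gives a reason for this result. From the compounds shown here alone, whether an amine or a carboxylic acid on the phenyl ring at this place would produce a step beyond the scatter stays open. So does the effect of a longer chain between that ring and the shared core.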